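The compounds below may be only part of what the source reports. "The series", "measured", "known", "first", "only" and "open" are said of these compounds alone.

In a physicochemical assay for lipophilicity (on this read-out lower numbers stand for lower lipophilicity and higher numbers for higher lipophilicity), compound 3 (`CCCCCCN(CCCCCSc1nc2cc([N+](=O)[O-])ccc2[nH]1)C(=O)Nc1ccc(F)cc1F`) gives 7.19, within the scatter of compound 1 (`CCCCCCN(CCCCCSc1nc2ccccc2o1)C(=O)Nc1ccc(F)cc1F`) at 7.18, while compound 2 (`CCCCCCN(CCCCCSc1nc2c([nH]1)CCCC2)C(=O)Nc1ccc(F)cc1F`) stands lower at 6.81. Compound 4 (`CCCCCCN(CCCCCSc1nc2c[nH]cnc-2n1)C(=O)Nc1ccc(F)cc1F`) differs from compound 3 thus: a group of 9 heavy atoms (5 carbon, 4 nitrogen; one five-membered aromatic ring with 2 hetero atoms, one six-membered aromatic ring with 2 hetero atoms) in place of a group of 12 heavy atoms (7 carbon, 3 nitrogen, 2 oxygen; one five-membered aromatic ring with 2 hetero atoms, one six-membered aromatic ring of carbon only), on a sulfur. The measured swaps on this sulfur are a number 0.01 log units higher from compound 1 to compound 3 (within the scatter), a number 0.37 log units lower from compound 1 to compound 2 (beyond the scatter) and a number 0.38 log units higher from compound 2 to compound 3 (beyond the scatter). The last joins a group of 9 heavy atoms to a group of 12 heavy atoms, the same sizes as here but in the opposite sense, so it is the nearest guide. Going by the values given here, no measured step brings in a six-membered aromatic ring with 2 hetero atoms, so the guide is only partial. The step expected in this assay is downward and larger than that guide: a number 0.89 log units lower from compound 3 to compound 4 (beyond the scatter). For compound 4 the estimated value is 6.3, with an expected range from 5.8 to 6.8.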

Compound 4, partition coefficient: 5.26
For compound 4 the middle estimate is 1.04 log units above the measured one; the whole stated range lies above it.
By their numbers in this assay, from the lowest: compound 4; then compound 2; then compounds 1 and 3 (each within the scatter of the next).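

On this sulfur, in this assay the group of compound 4 gives a number 1.93 log units lower from compound 3 to compound 4 (beyond the scatter) and a number 1.92 log units lower from compound 1 to compound 4 (beyond the scatter), both larger than any earlier step at this position. Heavy-atom count alone does not track the number: one group of 9 heavy atoms in place of another gives a number 1.55 log units lower from compound 2 to compound 4 (beyond the scatter) here. No evidence at hand bears on the origin of this drop.

Open, going by these compounds, is whether the nitrogens of the six-membered aromatic ring or the group as a whole carry the step. On these data alone, how an amine or a carboxylic acid on the group would compare also stays open.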